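Sulfur-to-selenium swap on the chloro-alkyne arm

This account rests on a few compounds, and the source may have more. Where it says the series, first, only, none or still open, it means among the compounds named here.

Of the compounds shown here, two have numbers so far. Compound 1 `CSc1cnc2ccccc2c1[Se]CC#CCOC(=O)c1ccc(C(=O)O)cc1` gives 3.1 ug/mL in a functional assay on B16 cells (Mus musculus) for antiproliferative activity, with a stated time of 72 h; on this read-out higher numbers stand for weaker inhibition and lower numbers for stronger inhibition. Compound 2 `OCC#CCSc1cnc2ccccc2c1SCC#CCCl` gives 43.4 ug/mL in this assay, the highest of the two numbers, with compound 1 standing a good deal lower and beyond the scatter. For the measured compounds named here, no single-point step between measured compounds is available, so the two values can only be read side by side, and the two structures differ in more than one place.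

Compound 3 `OCC#CCSc1cnc2ccccc2c1[Se]CC#CCCl` is not yet measured in this assay. It differs from compound 2 by a group of 6 heavy atoms (4 carbon, 1 chlorine, 1 selenium; no ring) in place of a group of 6 heavy atoms (4 carbon, 1 sulfur, 1 chlorine; no ring), on an aromatic carbon. Going by the values given here, the only other compound that carries selenium at this position, compound 1, shows 3.1 ug/mL, but its other arm is different, so that number cannot be carried over directly. A modest step toward a lower number is expected, a 1.7-fold lower number from compound 2 to compound 3 (0.24 log units; within the scatter), close to the scatter. Compound 3 is estimated at 25 ug/mL, within 8 ug/mL to 60 ug/mL.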

Compound 3, concentration for 50% inhibition: 3.8 ug/mL
For compound 3 the middle estimate is 6.6-fold (0.82 log units) above the measured one; measured number outside the range, below it.
By their numbers in this assay, from the lowest: compounds 1 and 3 (each within the scatter of the next); then compound 2.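

In this assay, for the compounds shown here, the exchange of sulfur for selenium on the chloro-alkyne arm gives an 11-fold lower number from compound 2 to compound 3 (1.06 log units; beyond the scatter) and is the first change that can be read at a single place. This aromatic carbon, opposite the ring nitrogen, therefore responds strongly to the identity of this one linking atom, with the hydroxyl-ended arm and the shared core unchanged. Nothing at hand bears on the origin of this step.

Still open, going by these compounds, is whether the selenium gain holds with other arm ends, such as an amine or a longer chain in place of the terminal chlorine. Equally open, on these data alone, is whether the same exchange at the sulfur of the hydroxyl-ended arm would shift the number in the same direction.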